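This account rests on a few compounds, and the source may have more. Where it says the series, first, only, none or still open, it means among the compounds named here.

Compound 3 `CCOC(=O)c1c(-c2ccc(Cl)cc2)cc(-c2ccccc2)nc1Nc1ccc(OC)cc1` gives 39.6% in a functional assay on the whole organism (strain Wister albino) for inhibition, with Rattus norvegicus as the target, read by paw edema, with stated times of 1 h and 24 h, at a dose of 50 mg/kg by the intraperitoneal route (on this read-out lower numbers stand for less inhibition and higher numbers for more inhibition at the one dose given (going by the name of the read-out)), the second highest of the three numbers in hand. Compound 1 `CCOC(=O)c1c(-c2ccc(Cl)cc2)cc(-c2ccccc2)nc1N1CCCCC1` gives 36.4% and compound 2 `CCOC(=O)c1c(-c2ccc(Cl)cc2)cc(-c2ccccc2)nc1Nc1ccccc1` gives 46.5%; the steps read a number 10.1 percentage points higher from compound 1 to compound 2 (beyond the scatter), a number 3.2 percentage points higher from compound 1 to compound 3 (within the scatter) and a number 6.9 percentage points lower from compound 2 to compound 3 (within the scatter). Compound 4 `CCOC(=O)c1c(-c2ccc(Cl)cc2)cc(-c2ccccc2)nc1Nc1ccc(Cl)cc1` differs from compound 3 by chloro in place of methoxy on an aromatic carbon. Among the compounds with values here, the only measured step at that aromatic carbon is the one in which methoxy replaced hydrogen, a number 6.9 percentage points lower from compound 2 to compound 3 (within the scatter), and it stayed within the scatter; no chloro analogue at that place has been measured. The expected step of a number 3.4 percentage points higher from compound 3 to compound 4 (within the scatter) is therefore none beyond the scatter, in no set direction. Compound 4 is estimated at 43%, in the range 31% to 55%.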

Compound 4, a percentage reported as inhibition, in the whole organism at one dose (the size of the read-out at that dose, not a potency): 32.9%
Compound 4: middle estimate off by 10.1 percentage points, on the high side; the measured number falls inside the stated range.
By their numbers in this assay, from the lowest: compounds 4, 1, 3 and 2 (each within the scatter of the next, the first and the last beyond it).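

On the shared core, chloro in place of hydrogen at this aromatic carbon gives the first change there beyond the scatter in this assay, a number 13.6 percentage points lower from compound 2 to compound 4 (beyond the scatter), while chloro in place of methoxy gives a number 6.7 percentage points lower from compound 3 to compound 4 (within the scatter). The step from piperidin-1-yl to (4-chlorophenyl)amino gives a number 3.5 percentage points lower from compound 1 to compound 4 (within the scatter), so the rise seen with plain anilino does not carry over to this chloro analogue. No evidence on hand accounts for these differences. Open, going by these compounds, is whether fluoro, methyl, an amine or a carboxylic acid at this aromatic carbon would read like compound 2 or like compound 4.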